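A 3-nitrophenyl swap among closely matched cytotoxicity values

The compounds below may be only part of what the source reports. "The series", "measured", "known", "first", "only" and "open" are said of these compounds alone.

In a functional assay on SMMC-7721 cells (Homo sapiens) for cytotoxicity, read by MTT assay, with a stated time of 24 h (a higher number here means a weaker inhibitor, a lower number a stronger inhibitor), compound 1 `O=C1/C(=C/c2ccccc2F)CN(S(=O)(=O)c2ccc(F)cc2)C/C1=C\c1ccccc1F` gives 8370 nM, compound 2 `CC(=O)Nc1ccc(S(=O)(=O)N2C/C(=C\c3ccccc3F)C(=O)/C(=C/c3ccccc3F)C2)cc1` gives 7490 nM and compound 3 `COc1cc(/C=C2\CN(S(=O)(=O)c3ccc(F)cc3)C/C(=C\c3cccc([N+](=O)[O-])c3)C2=O)cc(OC)c1OC` gives 4900 nM. Compound 2 stands within the scatter of both other compounds, so these numbers offer no ranking around it.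

Compound 4 `CC(=O)Nc1ccc(S(=O)(=O)N2C/C(=C\c3cccc([N+](=O)[O-])c3)C(=O)/C(=C/c3ccccc3F)C2)cc1` keeps the acetamido group of compound 2 and alters one aromatic substituent: 3-nitrophenyl in place of 2-fluorophenyl on a double-bonded chain carbon bound to a double-bonded ring carbon. Among the compounds with values here, the only measured single-place step is a 1.1-fold lower number from compound 1 to compound 2 (0.05 log units; within the scatter), for acetamido in place of fluoro on an aromatic carbon. That is a different change, and it stayed within the scatter. Within the data shown here, no measured step isolates the change to 3-nitrophenyl. Compound 2 and compound 3 differ in more than one place, yet compound 3, which carries the 3-nitrophenyl group, gives 4900 nM, within the scatter of compound 2.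

On this evidence, no step beyond the scatter is expected in this assay, and the estimate is a 1.2-fold lower number from compound 2 to compound 4 (0.10 log units; within the scatter). Compound 4 is expected at 6000 nM, with an estimated range of 3000 nM to 12000 nM.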

Compound 4, half-maximal inhibitory concentration: 10200 nM
Compound 4: the middle estimate sits 1.7-fold (0.23 log units) below what was measured; measured number inside the range.
By their numbers in this assay, from the lowest: compounds 3, 2, 1 and 4 (each within the scatter of the next, the first and the last beyond it).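

In this assay, within the data shown here, the change to 3-nitrophenyl in place of 2-fluorophenyl on a double-bonded chain carbon bound to a double-bonded ring carbon now has a measured step of its own (a 1.4-fold higher number from compound 2 to compound 4 (0.13 log units; within the scatter)), which no earlier pair of compounds could supply. With the acetamido group held constant, this position accepts the exchange without a shift beyond the scatter, even though the entering group has 9 heavy atoms against 7 and 2 hydrogen-bond acceptors against 0. Nothing measured here on these groups accounts for the result, so it stands as an observation only.

The compounds shown leave open whether the same exchange would give a similar step in the setting of compound 1, where fluoro stands in place of acetamido, since this is the only reading of the change. They also leave open whether a different kind of group at this place, such as a phenyl ring carrying an amine or a carboxylic acid, would move the number in this assay beyond the scatter.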